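The compounds below may be only part of what the source reports. "The series", "measured", "known", "first", "only" and "open" are said of these compounds alone.

Compound 1 `Cc1cc(NC(=O)Nc2ccccc2N)c2ccccc2n1`: 300 10^-6 cm/s
Compound 2 `Cc1cc(NC(=O)Nc2ccc(F)cc2)c2ccccc2n1`: 801 10^-6 cm/s
Compound 3 `Cc1cc(NC(=O)Nc2ncccc2C)c2ccccc2n1`: 369 10^-6 cm/s

These numbers come from an ADME assay for permeability, using PAMPA, at pH 7.4; a lower number here means that the compound crosses the layer more slowly, a higher number that the compound crosses the layer faster. Compound 2 stands highest of the three: the step of a 2.7-fold higher number from compound 1 to compound 2 (0.43 log units; beyond the scatter) and the step of a 2.2-fold lower number from compound 2 to compound 3 (0.34 log units; beyond the scatter) both lie beyond the scatter, while the step of a 1.2-fold higher number from compound 1 to compound 3 (0.09 log units; within the scatter) does not. Compound 4 `COc1ccc(NC(=O)Nc2cc(C)nc3ccccc23)cc1` differs from compound 2 by methoxy in place of fluoro on an aromatic carbon. Among the measured compounds shown here, none of the measured steps changes a single group on an otherwise unchanged ring; each one swaps the whole ring on the amide-type nitrogen, and even those swaps moved this assay only modestly. A smaller change of this kind is therefore expected to give a step of no more than modest size, most likely within the scatter, with a slight lean downward. Compound 4 is estimated at 600 10^-6 cm/s, with a range from 350 10^-6 cm/s to 950 10^-6 cm/s. The expected step is a 1.3-fold lower number from compound 2 to compound 4 (0.13 log units; within the scatter).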

Compound 4, apparent permeability: 787 10^-6 cm/s
Beside the measured number, compound 4's estimate is 1.3-fold (0.12 log units) below it, within the range that was stated.
By their numbers in this assay, from the lowest: compounds 1 and 3 (each within the scatter of the next); then compounds 4 and 2 (each within the scatter of the next).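

Each earlier step swapped a whole ring, whereas this one changes only the group on the ring, para to a large group, and in this assay it gives a 1.0-fold lower number from compound 2 to compound 4 (0.01 log units; within the scatter) with no real change. At this position, then, methoxy in place of fluoro leaves the reading where it was, even though methoxy is larger and brings a hydrogen-bond acceptor. Nothing measured here offers a reason for this. From the compounds shown here alone, whether an amine or a carboxylic acid in the same place would also stay this close to compound 2 remains open.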